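A few compounds are considered here, and "the series" means these few. Any claim that something is new, unique, unknown or untested is made for them only; others in the source may bear on it.

In a functional assay on the whole organism (strain Sprague-Dawley) for inhibition, with Rattus norvegicus as the target (on this read-out higher numbers stand for an effect only at larger amounts of compound and lower numbers for an effect already at smaller amounts), three compounds have been measured. Compound 1 `COc1cccc2cc(C(=O)O)cnc12` gives 150 mg/kg. Compound 2 `O=c1c(-c2nn[nH]n2)c[nH]c2ccc(Cl)cc12` reaches only a limit of the assay, > 25 mg/kg. Compound 3 `O=c1c(-c2nn[nH]n2)c[nH]c2c(Cl)cc(Cl)cc12` likewise reaches only a limit of the assay, > 10 mg/kg. For the measured compounds named here, the single step between measured compounds that differ in one place, a step that the two limits leave unreadable from compound 2 to compound 3, cannot be read because compound 3 sits at the limit of > 10 mg/kg in this assay, at which 1 of the 3 values shown sits, and compound 2 sits at the limit of > 25 mg/kg in this assay, at which 1 of the 3 values shown sits. Compound 2 therefore stands among the limits rather than among the numbers, and the measurements do not separate it from compound 3 in this assay.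

Compound 4 `CCc1ccc2[nH]cc(-c3nn[nH]n3)c(=O)c2c1` differs from compound 2 in one place: ethyl in place of chloro on an aromatic carbon. Going by the values given here, no measured step concerns an ethyl in place of chloro; the only step available, a step that the two limits leave unreadable from compound 2 to compound 3, concerns chloro in place of hydrogen and is itself unreadable. So nothing measured points in either direction for this assay, and the account expects a step no larger than the scatter, with a real chance that compound 4 again reaches only a limit. The step from compound 2 to compound 4 that the estimate means, a step that the limit leaves unreadable from compound 2 to compound 4, is expected to be small. Compound 4 is estimated at 50 mg/kg, with a range from 15 mg/kg to 200 mg/kg.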

Compound 4, minimum effective dose: 0.625 mg/kg
Beside the measured number, compound 4's estimate is 80-fold (1.90 log units) above it; measured number below the stated range.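

In this assay, ethyl in place of chloro gives an at least 40-fold lower number from compound 2 to compound 4 (1.60 log units; beyond the scatter), the first step among these compounds that can be read, since the step from chloro in place of hydrogen remains unreadable. It shows that the group on this aromatic carbon, on the six-membered aromatic ring of carbon only, can shift the read-out far beyond the scatter, which compound 2 and compound 3 could not show, as each of them gives only a limit. The true size of the step stays open on one side, since the starting point of this step is a limit and not a number: the limit of > 25 mg/kg in this assay, at which 1 of the 4 values shown sits.

The compounds shown leave open whether the much lower number belongs to ethyl alone or would also come with a methyl, a longer chain such as propyl or butyl, or a methoxy at this place. They also leave open how an ethyl here would read with a second chloro on the ring, the other change that sets compound 3 apart from compound 2.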